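Notes on compound 2 to compound 3

The source may report more compounds than this note shows. Statements on the series, on what has been measured and on what is new or still open speak of the compounds shown alone.

Measured in a functional assay on MDA-MB-231 cells (Homo sapiens) for antiproliferative activity, read by MTT assay, with a stated time of 72 h; on this read-out lower numbers stand for stronger inhibition and higher numbers for weaker inhibition:
- Compound 1 `CC(C)c1cccc(NC(=O)CCc2cccc3c2B(O)OC3)c1`: 1600 nM
- Compound 2 `COc1cc(OC)cc(-c2cccc(NC(=O)CCc3cccc4c3B(O)OC4)c2)c1`: 40 nM

Compound 2 holds the lower of the two numbers in this assay. Among the measured compounds shown here, the only measured step, a 40-fold lower number from compound 1 to compound 2 (1.60 log units; beyond the scatter), is large and put 3,5-dimethoxyphenyl in place of isopropyl. Compound 3 `N#Cc1ccc(-c2cccc(NC(=O)CCc3cccc4c3B(O)OC4)c2)cc1` carries 4-cyanophenyl in place of 3,5-dimethoxyphenyl on an aromatic carbon. In words, 4-cyanophenyl replaces 3,5-dimethoxyphenyl on an aromatic carbon. For the measured compounds named here, the measured step bears only indirectly, since both groups contain a six-membered aromatic ring of carbon only and no measured step varies what that ring carries. A modest rise, far smaller than the measured step, is expected: a 2.0-fold higher number from compound 2 to compound 3 (0.30 log units; within the scatter). For compound 3 the estimated value is 80 nM, with an expected range of 20 nM to 400 nM.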

Compound 3, half-maximal inhibitory concentration: 380 nM
Beside the measured number, compound 3's estimate is 4.8-fold (0.68 log units) below it, within the range that was stated.
By their numbers in this assay, from the lowest: compound 2; then compound 3; then compound 1.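

In this assay, an aromatic ring at this position does not alone fix the number: what that ring carries counts, with a 9.5-fold higher number from compound 2 to compound 3 (0.98 log units; beyond the scatter) when 4-cyanophenyl replaces 3,5-dimethoxyphenyl. The 4-cyanophenyl group still keeps part of the gain over isopropyl, with a 4.2-fold lower number from compound 1 to compound 3 (0.62 log units; beyond the scatter) in the same direction as the step to the dimethoxyphenyl ring. Nothing available here explains the gap between the two rings.

The two rings differ in more than one feature, so the nitrile, its place on the ring and the missing methoxy groups remain unseparated. A phenyl ring carrying a single methoxy group, or an unsubstituted phenyl ring, would help to separate them.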